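The source may hold more compounds than are shown below. What is called first, only, known or untested is meant among the compounds shown, and "the series" means these compounds.

Compound 2 `COc1cccc2c1ccc(=O)n2CCCN1CCN(c2cccc(Cl)c2)CC1` carries a methoxy on the core of compound 1 `O=c1ccc2ccccc2n1CCCN1CCN(c2cccc(Cl)c2)CC1`. In an assay on cell membranes for binding affinity to Sigma non-opioid intracellular receptor 1 (Rattus norvegicus) (on this read-out higher numbers stand for weaker inhibition and lower numbers for stronger inhibition), compound 1 gives 620 nM and compound 2 gives 980 nM; the difference between them, a 1.6-fold higher number from compound 1 to compound 2 (0.20 log units; within the scatter), means the two numbers cannot be told apart. Compound 3 `COc1cccc2c1ccc(=O)n2CCCN1CCN(c2cccc(Br)c2)CC1` differs from compound 2 in one place: bromo in place of chloro on an aromatic carbon. Going by the values given here, no measured step swaps one halogen for another; the only step known concerns a methoxy and lies within the scatter. For this assay the expected step is a 1.1-fold lower number from compound 2 to compound 3 (0.04 log units; within the scatter). Compound 3 is estimated at 900 nM, with a range from 400 nM to 2000 nM.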

Compound 3, half-maximal inhibitory concentration: 150 nM
The estimate for compound 3 lay 6.0-fold (0.78 log units) above the measured number, and the stated range ends above it.
By their numbers in this assay, from the lowest: compound 3; then compounds 1 and 2 (each within the scatter of the next).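

In this assay, the change from 3-chlorophenyl to 3-bromophenyl gives a 6.5-fold lower number from compound 2 to compound 3 (0.82 log units; beyond the scatter). So this position on the aromatic ring responds to a swap of one heavy atom, whereas the earlier methoxy step on the core stayed within the scatter. Nothing measured here explains the difference between chloro and bromo.

From the compounds shown here alone, whether bromo has the same effect on the core of compound 1, without the methoxy, remains open. So does how iodo or a methyl group would read in this place.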